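The source may report more compounds than this note shows. Statements on the series, on what has been measured and on what is new or still open speak of the compounds shown alone.

Series notes. Compound 1 `CC(C)c1onc(-c2c(Cl)cccc2Cl)c1COc1ccc(NC(=O)c2ccc(C(=O)O)cc2)c(C(F)(F)F)n1`, compound 2 `CC(C)c1onc(-c2c(Cl)cccc2Cl)c1COc1ccc(N(C)Cc2cccc(C(=O)O)c2)c(C(F)(F)F)n1` and compound 3 `CC(c1ccc(OCc2c(-c3c(Cl)cccc3Cl)noc2C2CC2)nc1C(F)(F)F)N(C)c1ccc(C(=O)O)cc1` share one core and differ only in the acid-bearing arm. In an assay on isolated protein for agonist activity at Bile acid receptor (Homo sapiens), read by FRET (a higher number here means a larger maximal response, a lower number a smaller maximal response), compound 1 gives 109%, compound 2 gives 102% and compound 3 gives 102%. Among the measured compounds shown here, the single one-place step measured so far, a number 7 percentage points lower from compound 1 to compound 2 (within the scatter), rebuilds the acid-bearing arm without moving the maximal response beyond the scatter. Compound 3 stands level with compound 2 at the digits recorded, the two together at the low end of the three numbers; compound 1 sits furthest from compound 3, yet that gap is within the scatter, so no order among the three can be read.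

Compound 4 `CC(Oc1cccc(C(=O)O)c1)c1ccc(OCc2c(-c3c(Cl)cccc3Cl)noc2C2CC2)nc1C(F)(F)F` is the next point in the same arm: 3-carboxyphenoxy in place of (4-carboxyphenyl)(methyl)amino on a saturated chain carbon bound to an aromatic carbon and a saturated chain carbon. For the measured compounds named here, the only measured step that bears on it is the rebuilt arm from compound 1 to compound 2, which stayed within the scatter; the expectation for this assay is therefore a step of no more than the scatter in either direction, expressed as a number 2 percentage points lower from compound 3 to compound 4 (within the scatter). Compound 4 is estimated at 100%, expected to fall between 85% and 118%.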

Compound 4, largest response reached (reported as efficacy), in percent of the reference or control that the assay uses: 102%
Compound 4: middle estimate off by 2 percentage points, on the low side; low and high end bracket the measured number.
By their numbers in this assay, from the lowest: compounds 2, 3, 4 and 1 (each within the scatter of the next).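

On the saturated chain carbon bound to an aromatic carbon and a saturated chain carbon, the first change measured at this position, 3-carboxyphenoxy in place of (4-carboxyphenyl)(methyl)amino, gives in this assay no change at the digits printed from compound 3 to compound 4 (within the scatter). The earlier step rebuilt the arm of compound 1 to give compound 2, whereas this one shows that the maximal response also stays within the scatter when the methyl-bearing nitrogen gives way to an oxygen and the name of the arm moves from a 4-carboxy to a 3-carboxy form. Nothing measured accounts for this outcome, and the two parts of the change cannot be told apart from this single step.

Still open, on these data alone, is whether 4-carboxyphenoxy on the same carbon would also stay within the scatter of compound 3 and of compound 4, which would separate the exchange of nitrogen for oxygen from the shift of the carboxylic acid. Also open is whether the maximal response in this assay would hold with a tetrazole in place of the carboxylic acid, since every compound shown carries that acid.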